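Three inactive sulfonamides and a dichlorophenyl analogue

A few compounds are considered here, and "the series" means these few. Any claim that something is new, unique, unknown or untested is made for them only; others in the source may bear on it.

Compound 1 `O=S(=O)(NC1=NCCN1C(=S)SN1CCn2c1nsc2=S)c1ccc(C(F)(F)F)cc1` gives in a functional assay on KYSE-510 cells (Homo sapiens) for antiproliferative activity, read by crystal violet staining, with a stated time of 96 h (a lower number here means a stronger inhibitor of growth, a higher number a weaker inhibitor of growth), only the limit >= 20000 nM.
Compound 2 `COc1ccc(S(=O)(=O)NC2=NCCN2C(=S)SN2CCn3c2nsc3=S)cc1` gives in this assay only the limit >= 20000 nM.
Compound 3 `O=S(=O)(NC1=NCCN1C(=S)SN1CCn2c1nsc2=S)c1ccc(OC(F)(F)F)cc1` gives in this assay only the limit >= 20000 nM.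

Compound 2 thus stands at the limit, as do the other two: the limit of >= 20000 nM in this assay, at which 3 of the 3 values shown sit. The steps a step that the two limits leave unreadable from compound 1 to compound 2, a step that the two limits leave unreadable from compound 1 to compound 3 and a step that the two limits leave unreadable from compound 2 to compound 3 therefore cannot be read in size or direction. Compound 4 `O=S(=O)(NC1=NCCN1C(=S)SN1CCn2c1nsc2=S)c1ccc(Cl)c(Cl)c1` differs from compound 2 by 3,4-dichlorophenyl in place of 4-methoxyphenyl on a sulfonyl sulfur. No measured step bears on this change in a readable way, and nothing shows any of these compounds as growth inhibitors below the limit. Compound 4 is therefore expected to stay near the limit, with an expected step of a number no higher from compound 2 to compound 4 (the limit leaves the size open). The estimate for compound 4 in this assay is 20000 nM, between 5000 nM and 50000 nM.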

Compound 4, concentration for 50% growth inhibition: >= 20000 nM
Compound 4: only a limit was reported (the forecaster's own chance of this, stated with the estimate: 75%); the middle value lies on the limit itself.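

Compound 4, like compound 1 and compound 2, gives only a limit, so the steps to compound 4 cannot be read in size or direction: the limit of >= 20000 nM in this assay, at which 4 of the 4 values shown sit.

The compounds shown leave open whether any group on the sulfonyl sulfur can bring growth inhibition in this assay past this limit.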